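A few compounds are considered here, and "the series" means these few. Any claim that something is new, unique, unknown or untested is made for them only; others in the source may bear on it.

Series notes. The shared core is that of compound 1 `COc1ccc(/C=C/C(=O)c2cccc(-c3cccc(F)c3)c2)cc1`, which in a functional assay on CNE-2 cells (Homo sapiens) for cytotoxicity, read by sulforhodamine B assay, with a stated time of 48 h (on this read-out lower numbers stand for stronger inhibition and higher numbers for weaker inhibition), gives 740 nM; this is the only numerical result in the set so far. Compound 2 `COc1ccc(/C=C/C(=O)c2cccc(-c3cccc(F)c3)c2)cc1O` in this assay gives "not determined" (no result reported), so it adds nothing to the numbers. Compound 3 `COc1ccc(/C=C/C(=O)c2cccc(Br)c2)cc1` likewise gives "not determined" (no result reported) in this assay. Among the measured compounds shown here, no pair of measured compounds that differ in one place is at hand, and no measured step can be drawn from the set.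

Compound 4 `O=C(/C=C/c1ccc(Br)cc1)c1cccc(-c2cccc(F)c2)c1` is not yet measured. It differs from compound 1 in one place: bromo in place of methoxy on an aromatic carbon. The exchange sits on an aromatic carbon of a six-membered aromatic ring of carbon only, para to a large group; read one bond further out, 4-methoxyphenyl becomes 4-bromophenyl. Nothing in the set shows what this swap does in this assay, since compound 3, the only other bromo-bearing entry, carries no number. The step is expected to be small, at the edge of the scatter and, if anything, toward weaker inhibition, so that a 1.6-fold higher number from compound 1 to compound 4 (0.21 log units; within the scatter) is the expected outcome. Compound 4 is expected to give 1200 nM in this assay, within a range from 400 nM to 4000 nM.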

Compound 4, half-maximal inhibitory concentration: 10500 nM
Beside the measured number, compound 4's estimate is 8.8-fold (0.94 log units) below it; the whole stated range lies below it.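

In this assay, among the compounds shown here, the aromatic carbon para to a large group proves sensitive to its substituent: bromo in place of methoxy gives a 14-fold higher number from compound 1 to compound 4 (1.15 log units; beyond the scatter), the first measured step and one that lies beyond the scatter. Within this single pair, 4-methoxyphenyl gives the stronger inhibition and 4-bromophenyl the weaker, so the two groups are not interchangeable at this place on the core of compound 1. No measurement shown bears on why the step is this large.

One pair cannot tell whether the weaker inhibition of compound 4 belongs to bromo itself or simply follows from the loss of methoxy, and an amine, an ethoxy group or a plain hydrogen at this place would help separate those two readings. Steps involving compound 2 and compound 3 cannot be read, so the effect of a hydroxy group on the methoxy-bearing ring and the contribution of the 3-fluorophenyl group also remain open.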